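The source may report more compounds than this note shows. Statements on the series, on what has been measured and on what is new or still open speak of the compounds shown alone.

The series opens with compound 1 `O=C(NC(=S)Nc1cccc(-c2nc3ccccc3[nH]2)c1)c1ccc2c(c1)OCCO2`, which in a functional assay on HUVEC cells (Homo sapiens) for inhibition, read by colorimetric assay and crystal violet staining, with a stated time of 72 h (on this read-out lower numbers stand for stronger inhibition and higher numbers for weaker inhibition), is recorded only at the limit of < 100 nM, a bound of the assay rather than a number. Compound 2 `Cc1ccc(-c2nc3ccccc3[nH]2)cc1NC(=S)NC(=O)c1ccccc1` stands at the opposite end: in this assay it is recorded only at the limit of > 10000 nM, again a bound rather than a number. Of the two values shown, that of compound 2 sits at the weak end of the read-out and that of compound 1 at the strong end, with nothing in between to mark a step.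

Compound 3 `Cc1ccc(-c2nc3ccccc3[nH]2)cc1NC(=S)NC(=O)c1ccc2c(c1)OCCO2` differs from compound 2 in one place: 2,3-dihydro-1,4-benzodioxin-6-yl in place of phenyl on a carbonyl carbon. The same dihydrobenzodioxinyl group is carried by compound 1, which gives < 100 nM in this assay. On that basis the change from compound 2 to compound 3 is expected to move the number toward stronger inhibition, by an at least 10-fold lower number from compound 2 to compound 3 (1.00 log units; beyond the scatter), a step expected to lie well beyond the usual scatter. Compound 3 is therefore estimated at 1000 nM in this assay, with a plausible range from 100 nM to 10000 nM.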

Compound 3, half-maximal inhibitory concentration: 150 nM
Beside the measured number, compound 3's estimate is 6.7-fold (0.82 log units) above it; the measured number falls inside the stated range.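

On a carbonyl carbon whose other neighbour is an amide-type nitrogen, 2,3-dihydro-1,4-benzodioxin-6-yl in place of phenyl gives an at least 66-fold lower number from compound 2 to compound 3 (1.82 log units; beyond the scatter) in this assay, so this single change is now seen to carry a compound from the weak end of the read-out to a measured number. That step is only a floor, because the value it starts from is a limit of the assay: the limit of > 10000 nM in this assay, at which 1 of the 3 values shown sits. Methyl in place of hydrogen on an aromatic carbon gives an at least 1.5-fold higher number from compound 1 to compound 3 (0.17 log units; that floor lies within the scatter), a floor within the scatter that neither shows nor rules out a real effect of the methyl group, because the value it starts from is a limit of the assay: the limit of < 100 nM in this assay, at which 1 of the 3 values shown sits.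

The compounds shown leave open whether the step depends on the oxygen atoms of the added ring or on the larger group as a whole, which a 3,4-dimethoxyphenyl or a naphthyl group on the same carbonyl carbon would help to separate. Also open, as far as these compounds go, is how a chlorine atom or a methoxy group would compare with the methyl on that aromatic carbon.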